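From 3,4-dimethoxyphenyl to 4-chlorophenyl on a sulfur

The compounds below may be only part of what the source reports. "The series", "measured", "known", "first", "only" and "open" are said of these compounds alone.

Measured so far in a functional assay on HCT-116 cells (Homo sapiens) for inhibition, read by CCK-8 assay, with a stated time of 72 h, tested at 2 uM; a lower number here means less inhibition of growth, a higher number more inhibition of growth at the concentration tested:
Compound 1 `COc1ccc(SCc2ccc(/C=C/C(=O)Nc3ccccc3N)cc2)cc1OC`: 12.9%
Compound 2 `Cc1cc(C)cc(SCc2ccc(/C=C/C(=O)Nc3ccccc3N)cc2)c1`: 7.98%

Only these two compounds have been measured, and compound 1 stands within the scatter of compound 2, so neither can be ranked above the other. Compound 3 `Nc1ccccc1NC(=O)/C=C/c1ccc(CSc2ccc(Cl)cc2)cc1` has not yet been measured. It keeps the core of compound 1 and alters a single group: 4-chlorophenyl in place of 3,4-dimethoxyphenyl on a sulfur. Among the measured compounds shown here, one measured step bears on this place, namely a number 4.9 percentage points lower from compound 1 to compound 2 (within the scatter). For the measured compounds named here, that step brings in a different group, and no measured compound carries 4-chlorophenyl, so it offers only thin guidance. No change beyond the scatter is therefore expected in this assay. The expected step is a number 0.9 percentage points lower from compound 1 to compound 3 (within the scatter). For compound 3 the estimated value is 12%, with an expected range from 3% to 28%.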

Compound 3, percent growth inhibition at one concentration: 5.62%
Beside the measured number, compound 3's estimate is 6.4 percentage points above it, and the stated range covers the measured number.
By their numbers in this assay, from the lowest: compounds 3, 2 and 1 (each within the scatter of the next).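

In this assay the change to 4-chlorophenyl, which carries chlorine and no hydrogen-bond acceptors, gives a number 7.3 percentage points lower from compound 1 to compound 3 (within the scatter) and, set against 3,5-dimethylphenyl, gives a number 2.4 percentage points lower from compound 2 to compound 3 (within the scatter) as well. The place on the sulfur has now held three differently substituted phenyl groups with no step beyond the scatter, so on these numbers a chlorine there cannot be told apart from the methoxy or methyl groups. Nothing at hand bears on why the numbers fall as they do.

Still open, from the compounds shown here alone, is whether something other than a substituted phenyl on that sulfur, such as an amine, a carboxylic acid or a longer chain, would move the number beyond the scatter. Also open, going by these compounds, is how these three compounds would compare at any other concentration.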